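Swapping Cyano for Methyl on a Dual-Ring Amide

A few compounds are considered here, and "the series" means these few. Any claim that something is new, unique, unknown or untested is made for them only; others in the source may bear on it.

Within the data shown here, compound 2 `N#Cc1ccc(-c2ncccn2)c(C(=O)N2CC3(CC3)C[C@H]2CNc2ccc(C(F)(F)F)cn2)c1` gives 8 in a functional assay on CHO cells for antagonist activity at Orexin/Hypocretin receptor type 1 (Homo sapiens), read by FLIPR and calcium flux (a higher number here means a more potent compound, by a factor of ten per unit of this negative logarithm, a lower number a less potent compound), the higher of the two numbers known so far; compound 1 `O=C(c1nc(C(F)(F)F)ccc1-c1ncccn1)N1CC2(CC2)C[C@H]1CNc1ccc(C(F)(F)F)cn1` gives 6.7, a gap beyond the scatter. Compound 3 `Cc1ccc(-c2ncccn2)c(C(=O)N2CC3(CC3)C[C@H]2CNc2ccc(C(F)(F)F)cn2)c1` carries methyl in place of cyano on an aromatic carbon. Among the measured compounds shown here, no measured pair shows this exact change, so the size of the step must be judged without a direct precedent; a moderate loss, somewhat beyond the scatter, seems the likelier outcome, though a flat result cannot be excluded. Compound 3 is therefore expected to reach 7.5, within 6.8 to 8.2, which would be a step of a number 0.50 log units lower from compound 2 to compound 3 (beyond the scatter).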

Compound 3, negative logarithm of the antagonist equilibrium constant: 8.7
For compound 3 the middle estimate is 1.20 log units below the measured one; measured number outside the range, above it.
By their numbers in this assay, from the lowest: compound 1; then compound 2; then compound 3.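

On this aromatic carbon, para to the pyrimidin-2-yl group, methyl in place of cyano brings a number 0.70 log units higher from compound 2 to compound 3 (beyond the scatter) in this assay, so a high number at this position does not depend on the hydrogen-bond acceptor of the cyano group. The smaller group, with a single carbon, serves at least as well here. Nothing on hand explains why the number rises. As far as these compounds go, whether an ethyl group, a chlorine atom or a methoxy group at this carbon would match methyl remains open, as does whether the gain would carry over to other cores.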